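An Azide Gives Way to a Pyrrolidine Amide

The source may report more compounds than this note shows. Statements on the series, on what has been measured and on what is new or still open speak of the compounds shown alone.

Among the measured compounds shown here, in a functional assay on HL-60 cells (Homo sapiens) for antiproliferative activity, read by MTT assay, with a stated time of 48 h (a higher number here means a weaker inhibitor, a lower number a stronger inhibitor), compound 2 `CC(C)=CCC[C@]1(C)/C=C/[C@@H](OC(=O)C=C(C)C)[C@](C)(O)/C=C/C(=O)/C(CN=[N+]=[N-])=C\C1` gives 910 nM, the highest of the two numbers so far, though compound 1 `CC(C)=CCC[C@]1(C)/C=C/[C@@H](OC(=O)C=C(C)C)[C@](C)(O)/C=C/C(=O)/C(CN(C(C)C)C(C)C)=C\C1` gives 740 nM and the step of a 1.2-fold higher number from compound 1 to compound 2 (0.09 log units; within the scatter) stays within the scatter. Compound 3 `CC(C)=CCC[C@]1(C)/C=C/[C@@H](OC(=O)C=C(C)C)[C@](C)(O)/C=C/C(=O)/C(C(=O)N2CCCC2)=C\C1` carries the change ((pyrrolidin-1-yl)carbonyl in place of azidomethyl on a double-bonded ring carbon). For the measured compounds named here, the one measured step involved neither an amide nor a ring and barely moved the number, so it bears only loosely here and points to no direction. Compound 3 is therefore expected to show a step of a 1.0-fold lower number from compound 2 to compound 3 (0.00 log units; within the scatter) that stays within the scatter. Compound 3 is estimated at 900 nM, with a range from 350 nM to 2500 nM.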

Compound 3, half-maximal inhibitory concentration: 12300 nM
Beside the measured number, compound 3's estimate is 14-fold (1.14 log units) below it; the measured number lies above the stated range.
By their numbers in this assay, from the lowest: compounds 1 and 2 (each within the scatter of the next); then compound 3.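

At this place the number does respond to the group: in this assay the (pyrrolidin-1-yl)carbonyl group brings a 14-fold higher number from compound 2 to compound 3 (1.13 log units; beyond the scatter) and a 17-fold higher number from compound 1 to compound 3 (1.22 log units; beyond the scatter) in one change. Both earlier groups reach the double-bonded ring carbon through a saturated chain carbon, whereas the new group reaches it through a carbonyl. Nothing measured here accounts for this rise. The compounds shown leave open whether the carbonyl or the pyrrolidine ring goes with the higher number. A (pyrrolidin-1-yl)methyl group at this place would separate the two.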